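The compounds below may be only part of what the source reports. "The series", "measured", "known", "first", "only" and "open" are said of these compounds alone.

Measured in a functional assay on CHO cells for antagonist activity at adenosine receptor A2b (Homo sapiens), read by 33P incorporation, with a stated time of 20 min (on this read-out lower numbers stand for stronger inhibition and higher numbers for weaker inhibition), so far: compound 1 `CCCn1c(-c2ccccc2)nc2c(NC3CCOC3)ncnc21` gives 9080 nM; compound 2 `CCn1c(-c2ccccc2)nc2c(NC3CCOC3)ncnc21` gives 11500 nM; compound 3 `Cn1c(-c2ccccc2)nc2c(NC3CCOC3)ncnc21` gives 13300 nM.

Compound 2 holds the second highest of these three numbers, and all three lie within the scatter of one another: a 1.3-fold higher number from compound 1 to compound 2 (0.10 log units; within the scatter) and a 1.2-fold higher number from compound 2 to compound 3 (0.06 log units; within the scatter). Compound 4 `CCn1c(-c2ccccc2)nc2c(NC3CCCC3)ncnc21` differs from compound 2 by cyclopentyl in place of oxolan-3-yl on a nitrogen on an aromatic ring. For the measured compounds named here, none of the measured steps touches this position; each of them, a 1.3-fold higher number from compound 1 to compound 2 (0.10 log units; within the scatter), a 1.5-fold higher number from compound 1 to compound 3 (0.17 log units; within the scatter) and a 1.2-fold higher number from compound 2 to compound 3 (0.06 log units; within the scatter), changes only the chain on the other aromatic nitrogen, and none moved beyond the scatter. There is therefore no measured guide to the direction of this change in this assay. Compound 4 is expected to stay near compound 2, estimated at 8000 nM within 2000 nM to 30000 nM, an expected step of a 1.4-fold lower number from compound 2 to compound 4 (0.16 log units; within the scatter).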

Compound 4, inhibition constant: 5790 nM
The estimate for compound 4 lay 1.4-fold (0.14 log units) above the measured number; the measured number falls inside the stated range.
By their numbers in this assay, from the lowest: compounds 4, 1, 2 and 3 (each within the scatter of the next, the first and the last beyond it).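

In this assay, for the compounds shown here, the first change at this nitrogen on an aromatic ring, cyclopentyl in place of oxolan-3-yl, gives a 2.0-fold lower number from compound 2 to compound 4 (0.30 log units; within the scatter). Removing the ring oxygen, and with it the one hydrogen-bond acceptor of this group, therefore leaves the two compounds indistinguishable on this read-out. Nothing available accounts for this result or bears on its cause.

On these data alone, whether a cyclohexyl ring, an open isopropyl chain or a pyrrolidin-3-yl ring at this position would move the number beyond the scatter remains open. So does whether cyclopentyl behaves alike with propyl or methyl on the other aromatic nitrogen.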